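The source may report more compounds than this note shows. Statements on the series, on what has been measured and on what is new or still open speak of the compounds shown alone.

Measured so far:
- compound 1 `C=CC(=O)Nc1cc2c(N3CCc4ccccc43)ncnc2cc1O[C@@H]1CCOC1`: 2710 nM
- compound 2 `C=C(C)C(=O)Nc1cc2c(N3CCc4ccccc43)ncnc2cc1O[C@@H]1CCOC1`: 4910 nM
- compound 3 `CCC/C=C/C(=O)Nc1cc2c(N3CCc4ccccc43)ncnc2cc1O[C@@H]1CCOC1`: 9230 nM

In a functional assay on PC-3 cells (Homo sapiens) for antiproliferative activity, read by MTT assay, with a stated time of 72 h (on this read-out lower numbers stand for stronger inhibition and higher numbers for weaker inhibition), compound 3 stands at the highest number of the three measured: one of the two gaps is a 1.9-fold higher number from compound 2 to compound 3 (0.27 log units; within the scatter) and lies within the scatter, the other is a 3.4-fold higher number from compound 1 to compound 3 (0.53 log units; beyond the scatter) and lies beyond it.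

Compound 4 `CCC/C=C/C(=O)Nc1cc2c(N3CCCc4ccccc43)ncnc2cc1O[C@@H]1CCOC1` differs from compound 3 in one place: 1,2,3,4-tetrahydroquinolin-1-yl in place of 2,3-dihydro-1H-indol-1-yl on an aromatic carbon. Among the measured compounds shown here, no measured step touches this place; all three measured steps, a 1.8-fold higher number from compound 1 to compound 2 (0.26 log units; within the scatter), a 3.4-fold higher number from compound 1 to compound 3 (0.53 log units; beyond the scatter) and a 1.9-fold higher number from compound 2 to compound 3 (0.27 log units; within the scatter), alter only the group on the carbonyl carbon and give no guide to the present change. With nothing bearing on it, no step beyond the scatter is expected in this assay in either direction.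

Compound 4 is therefore estimated at 9200 nM, in the range 3000 nM to 28000 nM. The expected step is a 1.0-fold lower number from compound 3 to compound 4 (0.00 log units; within the scatter).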

Compound 4, half-maximal inhibitory concentration: 11800 nM
Estimate against measurement, compound 4: 1.3-fold (0.11 log units) below; the measured number falls inside the stated range.
By their numbers in this assay, from the lowest: compounds 1, 2, 3 and 4 (each within the scatter of the next, the first and the last beyond it).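

In this assay, among the compounds shown here, the first change at this position, the six-membered non-aromatic ring of 1,2,3,4-tetrahydroquinolin-1-yl in place of the five-membered one of 2,3-dihydro-1H-indol-1-yl, gives a 1.3-fold higher number from compound 3 to compound 4 (0.11 log units; within the scatter). With pent-1-en-1-yl on the carbonyl carbon, the two groups therefore cannot be told apart at this position. Nothing available explains this result.

Still open, from the compounds shown here alone, is whether the same ring change behaves alike with vinyl on the carbonyl carbon, as in compound 1. Also open, going by these compounds, is how a morpholine or a plain aniline would read at this position.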